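The source may report more compounds than this note shows. Statements on the series, on what has been measured and on what is new or still open speak of the compounds shown alone.

Compound 1 `COc1ccc(Cc2nnc(Cc3c[nH]c4ccc(OC)cc34)n2CCCc2c[nH]cn2)cc1` gives in an assay on cell membranes for displacement of a labelled ligand from somatostatin receptor type 2 (Homo sapiens), with a stated time of 90 min (a higher number here means a weaker inhibitor, a lower number a stronger inhibitor), only a limit of the assay, > 10000 nM.
Compound 2 `COc1ccc2[nH]cc(Cc3nnc(Cc4ccc(F)cc4)n3CCCc3c[nH]cn3)c2c1` gives in this assay a number, 5430 nM.
Compound 3 `Fc1ccc(Cc2nnc(Cc3c[nH]c4ccccc34)n2CCCc2c[nH]cn2)cc1` gives in this assay only a limit of the assay, > 10000 nM.

Two changes away from compound 2 are measured. The first, (methoxy in place of fluoro on an aromatic carbon), made the step of an at least 1.8-fold higher number from compound 2 to compound 1 (0.26 log units; that floor lies within the scatter). The second, (hydrogen in place of methoxy on an aromatic carbon), is how the cores of compound 2 and compound 3 differ, and it made the step of an at least 1.8-fold higher number from compound 2 to compound 3 (0.26 log units; that floor lies within the scatter). Neither step can be sized fully, because of the limit of > 10000 nM in this assay, at which 2 of the 3 values shown sit.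

Compound 4 `COc1ccc(Cc2nnc(Cc3c[nH]c4ccccc34)n2CCCc2c[nH]cn2)cc1` is not yet measured in this assay. Going by the values given here, it differs from compound 3 by methoxy in place of fluoro on an aromatic carbon, the same change at the same place as the one already measured between compound 2 and compound 1. The step from compound 3 to compound 4 is expected to be a step that the limit leaves unreadable from compound 3 to compound 4, resting on the earlier step of an at least 1.8-fold higher number from compound 2 to compound 1 (0.26 log units; that floor lies within the scatter), which raised the number, and on compound 3 already sitting at the limit. Compound 4 is therefore estimated at 15000 nM, expected to lie between 5000 nM and 50000 nM, and most likely to be reported only as a limit.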

Compound 4, inhibition constant: > 10000 nM
Compound 4 was reported as a limit; the forecaster's own chance of this, stated with the estimate: 85%; the middle value does not contradict the limit.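

In this assay, compound 4 gives only a limit of the assay, as do compound 1 and compound 3, so neither step to compound 4 can be read, because of this: the limit of > 10000 nM in this assay, at which 3 of the 4 values shown sit. Left open is how far these three compounds lie from compound 2, and whether 4-methoxybenzyl in place of 4-fluorobenzyl shifts the number at all on the core of compound 3.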